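The source may hold more compounds than are shown below. What is called first, only, known or untested is meant among the compounds shown, and "the series" means these compounds.

Measured in a physicochemical assay for solubility, read by spectrophotometry, in phosphate buffer, with a stated time of 18 h, at pH 7.4; on this read-out lower numbers stand for lower solubility and higher numbers for higher solubility:
- compound 1 `Cc1nn(-c2ccccc2)c2nc(-c3ccc(C(C)C)cc3)c(C#N)c(-c3ccccc3O)c12`: 9800 nM
- compound 2 `Cc1nn(-c2ccccc2)c2nc(-c3ccc(F)cc3)c(C#N)c(-c3ccccc3O)c12`: 6000 nM

Not yet measured: compound 3 `Cc1nn(-c2ccccc2)c2nc(-c3ccc4c(c3)CCCC4)c(C#N)c(-c3ccccc3O)c12`.

Within the data shown here, compound 2 sits within the scatter of compound 1, the only other measured compound. The next change is 1,2,3,4-tetrahydronaphthalen-6-yl in place of 4-fluorophenyl on an aromatic carbon. Among the measured compounds shown here, one measured step bears on it, a change on the same aromatic group: a 1.6-fold lower number from compound 1 to compound 2 (0.21 log units; within the scatter). That step stayed within the scatter, so no step beyond the scatter is expected in this assay, though one step is thin evidence. The estimated 1.1-fold higher number from compound 2 to compound 3 (0.03 log units; within the scatter) is correspondingly small. Compound 3 is expected at 6500 nM, with an estimated range from 2500 nM to 14000 nM.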

Compound 3, solubility: 13000 nM
The estimate for compound 3 lay 2.0-fold (0.30 log units) below the measured number, and the stated range covers the measured number.
By their numbers in this assay, from the lowest: compounds 2, 1 and 3 (each within the scatter of the next, the first and the last beyond it).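

In this assay, the position next to the ring nitrogen now shows a step beyond the scatter: 1,2,3,4-tetrahydronaphthalen-6-yl in place of 4-fluorophenyl gives a 2.2-fold higher number from compound 2 to compound 3 (0.34 log units; beyond the scatter). Against 4-isopropylphenyl, the same group stays within the scatter, giving a 1.3-fold higher number from compound 1 to compound 3 (0.12 log units; within the scatter), so these two groups are not told apart at this position. Nothing on hand gives a cause for either step.

Open: whether an amine or a carboxylic acid on the aromatic ring at this position would shift the number further. From the compounds shown here alone, the effect of changing the 2-hydroxyphenyl group also remains open.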